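Azetidin-1-yl to pyridin-3-yl on the carbonyl of compound 1

The source may report more compounds than this note shows. Statements on the series, on what has been measured and on what is new or still open speak of the compounds shown alone.

In a functional assay on BXPC-3 cells (Homo sapiens) for antiproliferative activity, read by sulforhodamine B assay, with a stated time of 72 h (on this read-out higher numbers stand for weaker inhibition and lower numbers for stronger inhibition), compound 1 `CC(C)(C)c1[nH]cnc1/C=c1\[nH]c(=O)/c(=C/c2cccc(C(=O)N3CCC3)c2)[nH]c1=O` gives > 500 nM, which is a limit and not a number. Compound 2 `O=C(c1cccc(/C=c2\[nH]c(=O)/c(=C/c3ccccn3)[nH]c2=O)c1)N1CCC1` gives > 500 nM, also a limit. Compound 1 thus stands at the limit of > 500 nM in this assay, at which 2 of the 2 values shown sit.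

Compound 3 `CC(C)(C)c1[nH]cnc1/C=c1\[nH]c(=O)/c(=C/c2cccc(C(=O)c3cccnc3)c2)[nH]c1=O` carries pyridin-3-yl in place of azetidin-1-yl on a carbonyl carbon. Going by the values given here, the only measured step, a step that the two limits leave unreadable from compound 1 to compound 2, lies at another place and offers no size to carry over. A modest gain in this assay is tentatively expected, with its size poorly bounded. The expected step is an at least 2.5-fold lower number from compound 1 to compound 3 (0.39 log units; beyond the scatter). For compound 3 the estimate is 200 nM, with an expected range of 20 nM to 1000 nM.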

Compound 3, half-maximal inhibitory concentration: 4.05 nM
Compound 3: middle estimate off by 49-fold (1.69 log units), on the high side, and the stated range ends above it.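

Replacing azetidin-1-yl with pyridin-3-yl on a carbonyl carbon gives, in this assay, an at least 120-fold lower number from compound 1 to compound 3 (2.09 log units; beyond the scatter), so this place in the series can carry a large change in antiproliferative activity. The value of compound 1 is a limit, so the true size of this step stays bounded on one side only. Compound 3 is the only compound shown with a value off the limit: the limit of > 500 nM in this assay, at which 2 of the 3 values shown sit.

The step from compound 1 to compound 2 cannot be read. Open, from the compounds shown here alone, is whether a phenyl group on the carbonyl, lacking the ring nitrogen, would hold this gain.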